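Fluoro for Chloro on a Carboxy-Bearing Ring

The compounds below may be only part of what the source reports. "The series", "measured", "known", "first", "only" and "open" are said of these compounds alone.

Compound 1 `CC#CCn1c(N2CCC[C@@H](N)C2)cc(=O)n(Cc2ccc(Cl)c(C(=O)O)c2)c1=O` was tested in an assay on isolated protein for inhibition of Dipeptidyl peptidase 9 (Homo sapiens), read by fluorescence, with stated times of 15 min and 20 min; on this read-out lower numbers stand for stronger inhibition and higher numbers for weaker inhibition; in this assay compound 1 gives only a limit of > 100 nM, not a number. Compound 2 `CC#CCn1c(N2CCC[C@@H](N)C2)cc(=O)n(Cc2cccc(C(=O)OC)c2Br)c1=O` likewise gives only a limit of > 100 nM in this assay. Both results thus sit at one edge of the assay: the limit of > 100 nM in this assay, at which 2 of the 2 values shown sit. Compound 3 `CC#CCn1c(N2CCC[C@@H](N)C2)cc(=O)n(Cc2ccc(F)c(C(=O)O)c2)c1=O` differs from compound 1 by fluoro in place of chloro on an aromatic carbon. Going by the values given here, no step between measured compounds is available, so the expectation rests on compound 1 alone. In this assay the expected change is a step that the limit leaves unreadable from compound 1 to compound 3, nothing beyond the usual scatter. Compound 3 is therefore estimated at 250 nM, within 60 nM to 1500 nM.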

Compound 3, half-maximal inhibitory concentration: > 100 nM
Compound 3: only a limit was reported; the forecaster's own chance of this, stated with the estimate: 70%; the middle value is on the limit's open side.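

No step can be read from compound 1 to compound 3, since both results are limits and not numbers: the limit of > 100 nM in this assay, at which 3 of the 3 values shown sit.

Going by these compounds, what stays open is how strongly these compounds inhibit the enzyme, and whether fluoro in place of chloro changes that.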